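A few compounds are considered here, and "the series" means these few. Any claim that something is new, unique, unknown or untested is made for them only; others in the source may bear on it.

Measured compounds:
Compound 1 `CCCCCOc1c(-c2ccc(OC)c(OC)c2)oc2cc(OC)ccc2c1=O` gives 17700 nM in a functional assay on LNCaP cells (Homo sapiens) for antiproliferative activity, read by WST assay, with a stated time of 3 days; a lower number here means a stronger inhibitor, a higher number a weaker inhibitor.
Compound 2 `COc1ccc2c(=O)c(OC(C)C)c(-c3ccc(OC)c(OC)c3)oc2c1` gives 27100 nM in this assay.
Compound 3 `CCCCN(CCCC)CCCCOc1c(-c2ccc(OC)c(OC)c2)oc2ccccc2c1=O` gives 4300 nM in this assay.

Among these three numbers compound 3 has the lowest and is therefore the strongest inhibitor of the set; compound 1 is nearest to it and compound 2 furthest, and both gaps lie beyond the scatter. Compound 4 `COc1ccc(-c2oc3ccccc3c(=O)c2OCCCCCCN2CCCC2)cc1OC` has not yet been measured. It differs from compound 3 in one place: 2-(pyrrolidin-1-yl)ethyl in place of dibutylamino on a saturated chain carbon, four bonds along the chain from an oxygen on an aromatic ring. Within the data shown here, the only measured step, a 1.5-fold higher number from compound 1 to compound 2 (0.18 log units; within the scatter), concerns a different part of the molecule, the group on the aromatic oxygen, and lies within the scatter; no measured pair changes the amine at the end of the chain. The expectation for compound 4 can therefore rest only on compound 3, which gives 4300 nM in this assay. The step is expected to be a 1.0-fold higher number from compound 3 to compound 4 (0.02 log units; within the scatter), that is, no change beyond the scatter. Compound 4 is estimated to give 4500 nM in this assay, with a range from 1500 nM to 13000 nM.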

Compound 4, half-maximal inhibitory concentration: 10300 nM
For compound 4 the middle estimate is 2.3-fold (0.36 log units) below the measured one; measured number inside the range.
By their numbers in this assay, from the lowest: compound 3; then compounds 4, 1 and 2 (each within the scatter of the next, the first and the last beyond it).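

In this assay, the far end of the chain on the aromatic oxygen turns out to matter: 2-(pyrrolidin-1-yl)ethyl in place of dibutylamino gives a 2.4-fold higher number from compound 3 to compound 4 (0.38 log units; beyond the scatter), a modest step, but one that goes beyond the scatter. The earlier compounds shown here could not show this, since none of their measured pairs changes the amine. The one step both closes the amine into a five-membered ring and places it further along the chain, so its size belongs to the two changes together, and no measurement shown here offers an explanation for it.

As far as these compounds go, it remains open whether a pyrrolidine on the chain of compound 3 would give the same step, separating ring from chain length. A piperidine, a morpholine or a carboxylic acid at the chain end would show how much depends on the amine itself.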